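Swapping Phenyl for Furan-2-yl on a Quinolone Amide

This account rests on a few compounds, and the source may have more. Where it says the series, first, only, none or still open, it means among the compounds named here.

Measured compounds:
compound 1, `CCCn1cc(C(=O)NCc2ccccc2)c(=O)c2cc(F)c(N3CCC(C(N)=O)CC3)cc21`, giving 43700 nM;
compound 2, `CCn1cc(C(=O)O)c(=O)c2ccc(C(F)(F)F)cc21`, giving > 100000 nM;
compound 3, `CCCCn1cc(C(=O)NCc2ccccc2)c(=O)c2cc(F)c(N3CCC(C(N)=O)CC3)cc21`, giving 47000 nM.

The piece concerns an ADME assay on J774.1 cells (Mus musculus) for cytotoxicity, read by resazurin assay, with a stated time of 48 h; a higher number here means a weaker inhibitor, a lower number a stronger inhibitor. Compound 1 gives 43700 nM there, the lower of the two numbers recorded, with compound 3 next to it at 47000 nM. For compound 2 the result is a limit of the assay, > 100000 nM, and not a number (the limit of > 100000 nM in this assay, at which 1 of the 3 values shown sits).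

Among the compounds with values here, the only step between measured compounds runs a 1.1-fold higher number from compound 1 to compound 3 (0.03 log units; within the scatter), which changes nothing beyond the scatter. The unmeasured compound 4, `CCCn1cc(C(=O)NCc2ccco2)c(=O)c2cc(F)c(N3CCC(C(N)=O)CC3)cc21`, differs from compound 1 by furan-2-yl in place of phenyl on a saturated chain carbon bound to an amide-type nitrogen. Within the data shown here, no measured step touches the part of the molecule where this change sits, so the one measured step offers only a general indication that small changes at the edges of this shared core leave the reading in this assay roughly where it is.

Compound 4 is therefore expected to show a 1.0-fold higher number from compound 1 to compound 4 (0.01 log units; within the scatter), a move within the scatter. The estimate for compound 4 is 45000 nM, expected to fall between 20000 nM and 100000 nM.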

Compound 4, half-maximal inhibitory concentration: 56900 nM
For compound 4 the middle estimate is 1.3-fold (0.10 log units) below the measured one; measured number inside the range.
By their numbers in this assay, from the lowest: compounds 1, 3 and 4 (each within the scatter of the next). At a limit, above all of these: compound 2.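

In this assay, within the data shown here, this is the first reading of a change in the benzylcarbamoyl group, as the earlier step concerned only the chain on the aromatic nitrogen. Furan-2-yl in place of phenyl on a saturated chain carbon bound to an amide-type nitrogen gives a 1.3-fold higher number from compound 1 to compound 4 (0.11 log units; within the scatter), so exchanging a six-membered aromatic ring of carbon only for a five-membered one with 1 hetero atom and 1 hydrogen-bond acceptor leaves the reading within the scatter. This place therefore accepts this exchange without a measurable change in the number, just as the chain change gave a 1.1-fold higher number from compound 1 to compound 3 (0.03 log units; within the scatter) at the other place.

Going by these compounds, whether a pyridine ring, a carboxylic acid or a longer chain in place of the benzyl would shift the number beyond the scatter stays open, as does the effect of furan-2-yl on the butyl chain of compound 3. Nothing given here bears on why this step is as small as it is.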